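Microsomal half-life: trifluoromethoxy in place of a cyclopropyl group

The source may hold more compounds than are shown below. What is called first, only, known or untested is meant among the compounds shown, and "the series" means these compounds.

Compound 2 `CS(=O)(=O)Nc1ccc(CNC(=O)c2ccc(C3(C(F)(F)F)CC3)cc2)c(Cl)c1` stands highest of the two compounds measured in an ADME assay on microsomes from liver (Rattus norvegicus, strain Sprague-Dawley) for metabolic stability, read by HPLC, using NADPH, with stated times of 5 min and 60 min, tested at 10 uM (a higher number here means that the compound lasts longer, a lower number that the compound disappears faster), where compound 2 gives 3.03 h. Compound 1 `CC(C)S(=O)(=O)Nc1ccc(CNC(=O)c2ccc(C(C)(C)C)cc2)c(Cl)c1` in this assay gives 0.983 h, a lower number, and the gap between the two lies beyond the usual scatter of repeated measurements. Compound 3 `CS(=O)(=O)Nc1ccc(CNC(=O)c2ccc(OC(F)(F)F)cc2)c(Cl)c1` keeps the core of compound 2 and differs from it in one place: trifluoromethoxy in place of 1-(trifluoromethyl)cyclopropyl on an aromatic carbon. For the measured compounds named here, no measured pair shows this exchange, so no step can be read from the data, and the two measured compounds differ in more than one place. For this assay a small downward step is expected on going from compound 2 to compound 3, one that probably stays within the scatter. Compound 3 is estimated at 2 h, with a range from 0.8 h to 5 h. The expected step from compound 2 to compound 3 is a 1.5-fold lower number from compound 2 to compound 3 (0.18 log units; within the scatter).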

Compound 3, half-life: 2.47 h
For compound 3 the middle estimate is 1.2-fold (0.09 log units) below the measured one, and the stated range covers the measured number.
By their numbers in this assay, from the lowest: compound 1; then compounds 3 and 2 (each within the scatter of the next).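

In this assay, for the compounds shown here, the first single-place exchange at this aromatic carbon, trifluoromethoxy in place of 1-(trifluoromethyl)cyclopropyl, gives a 1.2-fold lower number from compound 2 to compound 3 (0.09 log units; within the scatter) and leaves compound 2 and compound 3 indistinguishable. On this shared core, therefore, a group with no ring reads the same, within the scatter, as a group with a three-membered carbon ring, and the read-out at this position does not depend on keeping that ring. Nothing measured here gives a reason for this match between the two groups.

Going by these compounds, whether a methoxy group or a carboxylic acid on this aromatic carbon would stay level with compound 2 and compound 3 remains open. Also open, on these data alone, is whether the same exchange would give a comparable step on the core of compound 1.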